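The source may hold more compounds than are shown below. What is called first, only, known or untested is meant among the compounds shown, and "the series" means these compounds.

In a functional assay on the whole organism (strain Wistar) for inhibition, with Rattus norvegicus as the target, with stated times of 30 min and 2 h, at a dose of 20 mg/kg by the oral route (on this read-out higher numbers stand for more inhibition at the one dose given (going by the name of the read-out) and lower numbers for less inhibition), compound 1 `O=C1OC(c2ccc(Cl)cc2)=C/C1=C\c1ccc(Cl)cc1Cl` gives 53.3%. Compound 2 `O=C1/C(=C/c2ccccc2)C=C(c2ccc(Cl)cc2)N1Cc1ccccc1` gives 24%, and compound 3 `O=C1/C(=C/c2ccc([N+](=O)[O-])cc2)C=C(c2ccc(Cl)cc2)N1Cc1ccccc1` gives 12%. Among these three numbers compound 3 stands lowest: compound 2 is its nearest neighbour and lies beyond the scatter above it, and compound 1 lies furthest above it, also beyond the scatter. For the measured compounds named here, the only measured step of a single change, nitro in place of hydrogen on an aromatic carbon, went a number 12 percentage points lower from compound 2 to compound 3 (beyond the scatter).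

Compound 4 `COc1cc(/C=C2\C=C(c3ccc(Cl)cc3)N(Cc3ccccc3)C2=O)ccc1O` differs from compound 3 in one place: 4-hydroxy-3-methoxyphenyl in place of 4-nitrophenyl on a double-bonded chain carbon bound to a double-bonded ring carbon. Going by the values given here, the ring carrying the nitro leaves, so the step from compound 2 to compound 3 is the only measured step that bears on this change, and it argues for a return toward the number of compound 2. What the hydroxy and methoxy contribute on their own is not shown by any measured pair, so the range must stay wide. The step is therefore expected to be a number 10 percentage points higher from compound 3 to compound 4 (within the scatter), upward and modest. In this assay compound 4 is expected to give 22%, between 8% and 40%.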

Compound 4, a percentage reported as inhibition, in the whole organism at one dose (the size of the read-out at that dose, not a potency): 36%
Estimate against measurement, compound 4: 14 percentage points below; the range from low to high includes it.
By their numbers in this assay, from the lowest: compound 3; then compound 2; then compound 4; then compound 1.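

In this assay, the aryl group on a double-bonded chain carbon bound to a double-bonded ring carbon can move the number upward as well as downward: 4-hydroxy-3-methoxyphenyl in place of 4-nitrophenyl gives a number 24 percentage points higher from compound 3 to compound 4 (beyond the scatter), and the same group in place of phenyl gives a number 12 percentage points higher from compound 2 to compound 4 (beyond the scatter). The earlier compounds shown here showed only a downward step at this position, so phenyl now sits between two substituted rings rather than marking the top of this small set. No measurement here accounts for the difference.

The compounds shown do not separate what the hydroxy and the methoxy each contribute. Also open, from the compounds shown here alone, is how an amine or a carboxylic acid on this aromatic ring would read, and whether 4-hydroxy-3-methoxyphenyl would raise the number on the core of compound 1.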